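Swapping the Aryl Group on the Chain-Borne Oxime Ether

A few compounds are considered here, and "the series" means these few. Any claim that something is new, unique, unknown or untested is made for them only; others in the source may bear on it.

Two nucleotide analogues sharing one core were tested in a functional assay on 1321-N1 cells for agonist activity at P2Y purinoceptor 4 (Homo sapiens), read by scintillation counting and inositol phosphate accumulation; a higher number here means that more compound is needed for the effect, a lower number that less compound is needed. Compound 1 `O=C(O)CCCO/N=c1/ccn([C@@H]2O[C@H](COP(=O)(O)OP(=O)(O)OP(=O)(O)O)[C@@H](O)[C@H]2O)c(=O)[nH]1` carries a carboxy group on the chain and gives 470 nM. For the measured compounds named here, compound 2 `O=c1[nH]/c(=N\OCCCc2cccc(F)c2)ccn1[C@@H]1O[C@H](COP(=O)(O)OP(=O)(O)OP(=O)(O)O)[C@@H](O)[C@H]1O`, in which that carboxy is replaced by 3-fluorophenyl, gives 100 nM, the lowest of the two numbers measured, and the step of a 4.7-fold lower number from compound 1 to compound 2 (0.67 log units; beyond the scatter) is the only step measured so far. Compound 3 `O=c1[nH]/c(=N\OCCCc2ccc(Br)cc2)ccn1[C@@H]1O[C@H](COP(=O)(O)OP(=O)(O)OP(=O)(O)O)[C@@H](O)[C@H]1O` has not yet been measured. It differs from compound 2 by 4-bromophenyl in place of 3-fluorophenyl on a saturated chain carbon, three bonds along the chain from an oxygen, a change from one aromatic ring to another at the same place on the chain. Going by the values given here, the measured step concerns trading a carboxy group for an aromatic ring, not trading one halogenated ring for another, so no measured step bears directly on this change. The expected step of no change at the digits printed from compound 2 to compound 3 (within the scatter) is therefore none beyond the scatter. In this assay compound 3 is estimated at 100 nM, with a range from 30 nM to 330 nM.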

Compound 3, half-maximal effective concentration: 141 nM
The estimate for compound 3 lay 1.4-fold (0.15 log units) below the measured number, and the stated range covers the measured number.
By their numbers in this assay, from the lowest: compounds 2 and 3 (each within the scatter of the next); then compound 1.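

In this assay, putting 4-bromophenyl in place of 3-fluorophenyl on a saturated chain carbon, three bonds along the chain from an oxygen, gives a 1.4-fold higher number from compound 2 to compound 3 (0.15 log units; within the scatter), so these two compounds cannot be told apart. For the compounds shown here, the earlier comparison involved only one aromatic ring, whereas a second ring now also gives a lower number than the carboxy group, with a 3.3-fold lower number from compound 1 to compound 3 (0.52 log units; beyond the scatter). No measurement available here explains why the two rings read alike.

The two rings differ in both the halogen and its place on the ring, and the compounds shown do not separate these two changes. Also open, from the compounds shown here alone, is how an unsubstituted phenyl, a ring bearing an amine, or a longer chain would read in this assay.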